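Metabolic stability notes on the ethyl homologue of compound 1

The compounds below may be only part of what the source reports. "The series", "measured", "known", "first", "only" and "open" are said of these compounds alone.

Measured so far:
compound 1, `CCC(=O)N[C@@H]1CCCc2c1cncc2N1C(=O)c2ccc(Cl)cc2[C@@H]1C`: < 3.5 mL/min/kg
compound 2, `CCC1c2cc(Cl)ccc2C(=O)N1c1cccnc1`: 6.6 mL/min/kg
compound 3, `CC1c2cc(Cl)ccc2C(=O)N1c1cccnc1`: 12.2 mL/min/kg

In an ADME assay on microsomes from liver (Homo sapiens) for metabolic stability, read by LC-MS, using NADPH, with stated times of 10 min and 30 min (on this read-out higher numbers stand for fast clearance and lower numbers for slow clearance), compound 3 gives 12.2 mL/min/kg and compound 2 gives 6.6 mL/min/kg. The change between them, (methyl in place of hydrogen on a saturated chain carbon bound to a saturated ring carbon), gave a 1.8-fold lower number from compound 3 to compound 2 (0.27 log units; within the scatter). Compound 1 gives only a limit in this assay, sitting at the limit of < 3.5 mL/min/kg in this assay, at which 1 of the 3 values shown sits. How the core of compound 1 differs from that of compound 3 is not broken down here.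

Compound 4, `CCC(=O)N[C@@H]1CCCc2c1cncc2N1C(=O)c2ccc(Cl)cc2[C@@H]1CC`, is not yet measured and carries the same change, (methyl in place of hydrogen on a saturated chain carbon bound to a saturated ring carbon). A step that the limit leaves unreadable from compound 1 to compound 4 is expected, resting on compound 1 standing at the limit of < 3.5 mL/min/kg in this assay, at which 1 of the 3 values shown sits, and on compound 3 to compound 2 giving a 1.8-fold lower number from compound 3 to compound 2 (0.27 log units; within the scatter). Compound 4 is therefore expected at 2.5 mL/min/kg, most likely again reported only as a limit, between 1 mL/min/kg and 5 mL/min/kg.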

Compound 4, clearance: < 3.5 mL/min/kg
Compound 4: only a limit was reported; the forecaster's own chance of this, stated with the estimate: 70%; the middle value lies beyond the limit too.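

Compound 1 and compound 4 both give only a limit, so no step between them can be read: the limit of < 3.5 mL/min/kg in this assay, at which 2 of the 4 values shown sit.

The compounds shown leave open whether the change from methyl to ethyl alters clearance on the core of compound 1.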